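The compounds below may be only part of what the source reports. "The series", "measured", "known", "first", "only" and "open" are said of these compounds alone.

In a functional assay on KB cells (Homo sapiens) for cytotoxicity (on this read-out higher numbers stand for weaker inhibition and lower numbers for stronger inhibition), compound 1 `Nc1nnc(O)c2c1c(Cl)cn2C1O[C@H](CO)[C@@H](O)[C@H]1O`, which carries chloro, gives 6100 nM, and compound 2 `C[C@@]1(O)C[C@H](N2C=C(Br)C3=C(N)N=NC(=O)C32)O[C@@H]1CO`, which carries bromo, gives 6700 nM. Compound 3 `Nc1nnc(O)c2c1ccn2C1CCC(CO)O1`, which carries neither halogen, reads > 100000 nM in this assay, and this is a limit of the assay, not a number. Compound 4 `Nc1nnc(O)c2c1c(Br)cn2C1CCC(CO)O1` is made from compound 3 by a single change: bromo in place of hydrogen on an aromatic carbon. The closest guide is compound 2 at 6700 nM, but it differs from compound 3 elsewhere too, so it guides only loosely. A clear move towards stronger inhibition is expected, an at least 3.3-fold lower number from compound 3 to compound 4 (0.52 log units; beyond the scatter). Compound 4 is estimated at 30000 nM, with an expected range of 6000 nM to 100000 nM.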

Compound 4, half-maximal inhibitory concentration: 10000 nM
Beside the measured number, compound 4's estimate is 3.0-fold (0.48 log units) above it; the measured number falls inside the stated range.
By their numbers in this assay, from the lowest: compounds 1, 2 and 4 (each within the scatter of the next). At a limit, above all of these: compound 3.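

In this assay, going by these compounds alone, bromo in place of hydrogen on this aromatic carbon is the one change that can be read on its own, and it gives an at least 10-fold lower number from compound 3 to compound 4 (1.00 log units; beyond the scatter). Compounds 1 and 2 also carry a halogen but differ from compound 3 elsewhere too, so they could not show this. The true size of the step stays unknown because compound 3 sits at a limit of the assay, not at a number: the limit of > 100000 nM in this assay, at which 1 of the 4 values shown sits.

Still open, on these data alone, is how chloro would read on the core of compound 4, and how an amine, a nitrile or a longer chain would read on this carbon.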